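Swapping the bicyclic ring on the ether oxygen

This account rests on a few compounds, and the source may have more. Where it says the series, first, only, none or still open, it means among the compounds named here.

Compound 2 `Cc1cc(Nc2ncnc3cc(O)c(NC(=O)/C=C/[C@H]4CCCN4C)cc23)ccc1Oc1ccc2nccn2c1` gives 5.22 nM in a functional assay on BT-474 cells (Homo sapiens) for inhibition, read by CellTiter-Glo, with a stated time of 72 h (on this read-out lower numbers stand for stronger inhibition and higher numbers for weaker inhibition), the highest of the two numbers recorded so far, while its nearest neighbour compound 1 `Cc1cc(Nc2ncnc3cc(O)c(NC(=O)/C=C/[C@H]4CCCN4C)cc23)ccc1Oc1ccn2ccnc2c1` gives 4.63 nM in this assay; the step of a 1.1-fold higher number from compound 1 to compound 2 (0.05 log units; within the scatter) lies within the scatter. Compound 3 `Cc1cc(Nc2ncnc3cc(O)c(NC(=O)/C=C/[C@H]4CCCN4C)cc23)ccc1Oc1ccn2ncnc2c1` has not been measured. Compared with compound 2 it carries a group of 9 heavy atoms (6 carbon, 3 nitrogen; one five-membered aromatic ring with 3 hetero atoms, one six-membered aromatic ring with 1 hetero atom) in place of a group of 9 heavy atoms (7 carbon, 2 nitrogen; one five-membered aromatic ring with 2 hetero atoms, one six-membered aromatic ring with 1 hetero atom), on an oxygen on an aromatic ring. Among the compounds with values here, the only measured step that bears on this change is a 1.1-fold higher number from compound 1 to compound 2 (0.05 log units; within the scatter), which also exchanged one bicyclic group for another on the same oxygen and produced no shift beyond the scatter. On that basis compound 3 is expected to stay close to compound 2, with the step of a 1.1-fold higher number from compound 2 to compound 3 (0.02 log units; within the scatter) expected to remain within the scatter. For compound 3 the estimated value in this assay is 5.5 nM, within a range from 2.5 nM to 12 nM.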

Compound 3, half-maximal inhibitory concentration: 2.4 nM
Beside the measured number, compound 3's estimate is 2.3-fold (0.36 log units) above it; measured number below the stated range.
By their numbers in this assay, from the lowest: compounds 3, 1 and 2 (each within the scatter of the next, the first and the last beyond it).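

On the oxygen on an aromatic ring, exchanging one bicyclic group for another now moves the number in this assay beyond the scatter (  a 2.2-fold lower number from compound 2 to compound 3 (0.34 log units; beyond the scatter)), which the earlier pair of compounds did not show. Within the data shown here, the entering group has 6 carbon and 3 nitrogen atoms, with 3 hetero atoms in its five-membered aromatic ring, yet the comparison with the other group of 7 carbon and 2 nitrogen atoms stays within the scatter (a 1.9-fold lower number from compound 1 to compound 3 (0.29 log units; within the scatter)), so the shift is seen against only one of the two neighbours. Nothing measured here accounts for that difference. The compounds shown leave open how the number would respond on this oxygen to a group without the fused five-membered ring, such as a plain phenyl ring or a methoxy group. They also leave open whether a group with a fourth ring nitrogen would keep the number in this range.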